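Aryl swap on the alkene of an aryl vinyl sulfone series

A few compounds are considered here, and "the series" means these few. Any claim that something is new, unique, unknown or untested is made for them only; others in the source may bear on it.

Measured compounds:
compound 1 `Cc1cc(C)cc(/C=C(\C(=O)c2ccc(Cl)cc2)S(=O)(=O)c2ccc(Br)cc2)c1`: 10000 nM
compound 2 `COc1ccccc1/C=C(/Sc1ccc(C)cc1)C(=O)c1ccc(Cl)cc1`: 25000 nM
compound 3 `Cc1cc(C)cc(/C=C(\C(=O)c2ccc(Cl)cc2)S(=O)(=O)Cc2ccc(Cl)cc2)c1`: 1000 nM

In a functional assay on DU-145 cells (Homo sapiens) for inhibition, read by trypan blue exclusion, with a stated time of 96 h (a lower number here means a stronger inhibitor of growth, a higher number a weaker inhibitor of growth), compound 1 gives 10000 nM, the second highest of the three numbers; compound 2 gives a higher number, and compound 3 the lowest. Among the measured compounds shown here, the one single-point step known is a 10-fold lower number from compound 1 to compound 3 (1.00 log units; beyond the scatter), a change at the sulfonyl sulfur, not on the chain carbon.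

Compound 4 `COc1ccc(/C=C(\C(=O)c2ccc(Cl)cc2)S(=O)(=O)c2ccc(Br)cc2)cc1` differs from compound 1 by 4-methoxyphenyl in place of 3,5-dimethylphenyl on a double-bonded chain carbon bound to a double-bonded chain carbon. For the measured compounds named here, no measured step changes this aryl group alone, so nothing directly bears on it; compound 2 carries a methoxyphenyl but differs in more than one place. In this assay the expected step is therefore no change at the digits printed from compound 1 to compound 4 (within the scatter), none beyond the scatter. Compound 4 is estimated at 10000 nM, within 3000 nM to 30000 nM.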

Compound 4, concentration for 50% growth inhibition: 10000 nM
Compound 4: middle estimate and measured number agree at the digits printed; the range from low to high includes it.
By their numbers in this assay, from the lowest: compound 3; then compounds 1 and 4 (each within the scatter of the next); then compound 2.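

In this assay, among the compounds shown here, this is the first direct reading of the aryl group on the double-bonded chain carbon: no change at the digits printed from compound 1 to compound 4 (within the scatter), with 4-methoxyphenyl in place of 3,5-dimethylphenyl. The swap brings in a hydrogen-bond acceptor by count, yet with the 4-bromophenyl group on the sulfonyl sulfur held fixed, the two aryl groups are not told apart in this assay. No evidence is available to explain this flat result.

From the compounds shown here alone, whether the same swap stays flat with the 4-chlorobenzyl group of compound 3 remains open. So does the outcome for an aryl group carrying an amine or a carboxylic acid at this position.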